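The source may hold more compounds than are shown below. What is called first, only, known or untested is meant among the compounds shown, and "the series" means these compounds.

Working notes on the series. Compound 1 `Cc1ccc(/N=C2\C(=O)Nc3ccc(S(=O)(=O)N4CCOCC4)cc32)cc1`, compound 2 `O=C1Nc2ccc(S(=O)(=O)N3CCOCC3)cc2/C1=N/c1ccc(O)cc1` and compound 3 `CC(=O)N/N=C1\C(=O)Nc2ccc(S(=O)(=O)N3CCOCC3)cc21` share a core and differ in the group on the double-bonded nitrogen. In an ADME assay on WI-38 cells (Homo sapiens) for cytotoxicity, read by sulforhodamine B assay, with a stated time of 24 h (on this read-out higher numbers stand for weaker inhibition and lower numbers for stronger inhibition), compound 1 gives 309000 nM, compound 2 gives 259000 nM and compound 3 gives 325000 nM. Compound 3 cannot be separated from the other two, and the remaining pair shows a 1.2-fold lower number from compound 1 to compound 2 (0.08 log units; within the scatter).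

The unmeasured compound 4 `N/N=C1\C(=O)Nc2ccc(S(=O)(=O)N3CCOCC3)cc21` has hydrogen in place of acetyl on an amine nitrogen. Cut one bond further out, this reads acetamido to amino. Within the data shown here, no measured step makes this exact change.

The closest evidence comes from the two steps that put acetamido in place of 4-methylphenyl or 4-hydroxyphenyl on a double-bonded nitrogen: a 1.1-fold higher number from compound 1 to compound 3 (0.02 log units; within the scatter) and a 1.3-fold higher number from compound 2 to compound 3 (0.10 log units; within the scatter). Both changed the whole group at this place and neither left the scatter, so no step beyond the scatter is expected in this assay, and neither direction is favoured. The expected step is a 1.1-fold lower number from compound 3 to compound 4 (0.03 log units; within the scatter). With only these compounds behind it, this expectation remains loose. The estimate for compound 4 is 300000 nM, with an estimated range of 150000 nM to 600000 nM.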

Compound 4, half-maximal inhibitory concentration: 391000 nM
Estimate against measurement, compound 4: 1.3-fold (0.12 log units) below; the measured number falls inside the stated range.
By their numbers in this assay, from the lowest: compounds 2, 1, 3 and 4 (each within the scatter of the next).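

In this assay, cutting the group on the double-bonded nitrogen back to amino does not separate compound 4 from the others: the loss of acetyl gives (a 1.2-fold higher number from compound 3 to compound 4 (0.08 log units; within the scatter)), and the exchanges of the two aromatic groups give (a 1.5-fold higher number from compound 2 to compound 4 (0.18 log units; within the scatter)) and (a 1.3-fold higher number from compound 1 to compound 4 (0.10 log units; within the scatter)). The earlier compounds had only shown exchanges among larger groups, whereas this change takes away all 3 heavy atoms of acetyl and leaves a bare amino group, and the number still stays within the scatter, so the position has so far tolerated both the aromatic groups and this minimal end of the range without a readable step. Nothing measured here explains why the numbers stay so close.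

From the compounds shown here alone, it remains open whether any group on this nitrogen can move the number beyond the scatter, for example a carboxylic acid in place of hydroxy on the aromatic carbon, or a longer alkyl chain in place of acetyl. Going by these compounds, it is also open whether the same insensitivity would hold for these groups on a changed core, since all four compounds share one core.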